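Nucleoside analogues on Vero cells: a limit-bound series

The source may hold more compounds than are shown below. What is called first, only, known or untested is meant among the compounds shown, and "the series" means these compounds.

Compound 1, `C[C@@]1(O)[C@H](O)[C@@H](CO)O[C@H]1n1cnc2c(ONC(=O)OCc3ccccc3)nc(N)nc21` — in an ADME assay on Vero cells (Chlorocebus sabaeus) for cytotoxicity, with a stated time of 3 days (a lower number here means that less compound is tolerated, a higher number that more compound is tolerated), compound 1 gives > 100000 nM, a limit of the assay rather than a number.
Compound 2, `CONc1nc(N)nc2c1ncn2[C@@H]1O[C@H](CO)[C@@H](O)[C@@]1(C)O` — in this assay compound 2 gives > 100000 nM, again only a limit.
Compound 3, `C[C@@]1(O)[C@H](O)[C@@H](CO)O[C@H]1n1cnc2c(N)nc(N=[N+]=[N-])nc21` — in this assay compound 3 gives > 100000 nM, once more a limit.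

Compound 3 therefore stands where every measured compound stands: at the limit of > 100000 nM in this assay, at which 3 of the 3 values shown sit. Within the data shown here, no measured pair differs in a single place, so no step size is known here. Compound 4, `CONc1nc(N)c2ncn([C@@H]3O[C@H](CO)[C@@H](O)[C@@]3(C)O)c2n1`, carries methoxyamino in place of azido on an aromatic carbon. Compound 2 already shows that a methoxyamino group on the shared core is tolerated up to the limit, and compound 4 is expected to behave the same way, with a number no higher from compound 3 to compound 4 (the limit leaves the size open) amounting to no change beyond the scatter. The expected value for compound 4 is 100000 nM, within 30000 nM to 100000 nM.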

Compound 4, half-maximal cytotoxic concentration: > 100000 nM
Compound 4 ended at the assay's limit; the forecaster's own chance of this, stated with the estimate: 85%; the middle value sits exactly at the limit.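

No step can be read from compound 3 to compound 4: both give only a limit in this assay. The compounds shown leave open what actual number any of them would give there, and whether methoxyamino in place of azido changes it.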